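Fluoro for Chloro on the Aryl Ring: Expected Effect

A few compounds are considered here, and "the series" means these few. Any claim that something is new, unique, unknown or untested is made for them only; others in the source may bear on it.

Among the three measured compounds, compound 2 `COc1ccc(C2C(C)C(=O)CC(c3ccc(Cl)cc3)N2C(=O)CN2CCN(C)CC2)cc1` gives 53.1% in a functional assay on the whole organism for inhibition, with Mus musculus as the target, in the writhing test, with a stated time of 1 h, at a dose of 60 mg/kg by the oral route (a lower number here means less inhibition, a higher number more inhibition at the dose given (going by the name of the read-out)), the second highest of the three numbers. Compound 3 `CC1C(=O)CC(c2ccc(F)cc2)N(C(=O)CCl)C1c1ccc(Cl)cc1` gives 57.6% in this assay, within the scatter of compound 2. Compound 1 `CC1C(=O)CC(c2ccc(Cl)cc2)N(C(=O)CN2CCN(C)CC2)C1c1ccc(N(C)C)cc1` gives 28.1% in this assay, the lowest of the three. Within the data shown here, the only step between compounds differing in one place is a number 25 percentage points higher from compound 1 to compound 2 (beyond the scatter), methoxy in place of dimethylamino on an aromatic carbon.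

Compound 4 `COc1ccc(C2C(C)C(=O)CC(c3ccc(F)cc3)N2C(=O)CN2CCN(C)CC2)cc1` differs from compound 2 by fluoro in place of chloro on an aromatic carbon. Among the measured compounds shown here, no measured step exchanges chloro for fluoro alone. Compound 3 carries fluoro on one ring and chloro on the other, but it differs from compound 2 in more than one place, so it offers no direct guide. For the measured compounds named here, with no step bearing on this change, and compound 2 standing at 53.1%, the expected step is a number 1.1 percentage points lower from compound 2 to compound 4 (within the scatter), none beyond the scatter. Compound 4 is therefore estimated at 52%, with a range from 35% to 70%.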

Compound 4, a percentage reported as inhibition, in the whole organism at one dose (the size of the read-out at that dose, not a potency): 55.2%
Estimate against measurement, compound 4: 3.2 percentage points below, within the range that was stated.
By their numbers in this assay, from the lowest: compound 1; then compounds 2, 4 and 3 (each within the scatter of the next).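

Among these compounds, the exchange of 4-chlorophenyl for 4-fluorophenyl gives the first direct reading of this position in this assay, with a number 2.1 percentage points higher from compound 2 to compound 4 (within the scatter) as the step. With the methoxy group and the rest of compound 2 held in place, chloro and fluoro at this position cannot be told apart in this read-out at this dose, whereas the step on the other aromatic ring, a number 25 percentage points higher from compound 1 to compound 2 (beyond the scatter), lies beyond the scatter. No measurement bears on why the two halogens give values within the scatter of each other.

As far as these compounds go, whether a bromo group, a hydrogen or an amine at this position would also stay within the scatter of compound 2 remains open. From the compounds shown here alone, it is also open whether fluoro in place of chloro would read the same with the dimethylamino group of compound 1 in place of the methoxy group.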